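A few compounds are considered here, and "the series" means these few. Any claim that something is new, unique, unknown or untested is made for them only; others in the source may bear on it.

Measured compounds:
- compound 1 `Cc1cc(Oc2ccc(Cn3nc4ccc(Cl)cc4c3C(=O)NS(=O)(=O)c3ccc(NCc4ccco4)c([N+](=O)[O-])c3)cc2)cc(C)c1Cl`: 570 nM
- compound 2 `Cc1cc(Oc2ccc(Cn3nc4ccc(Cl)cc4c3C(=O)NS(=O)(=O)c3ccc(NCc4cccnc4)c([N+](=O)[O-])c3)cc2)cc(C)c1Cl`: 1180 nM
- compound 3 `Cc1cc(Oc2ccc(Cn3nc4ccc(Cl)cc4c3C(=O)NS(=O)(=O)c3ccc([N+](=O)[O-])c(NCc4ccco4)c3)cc2)cc(C)c1Cl`: 960 nM

All three were tested in an assay on isolated protein for inhibition of Apoptosis regulator Bcl-2 (Homo sapiens), read by fluorescence polarization; on this read-out lower numbers stand for stronger inhibition and higher numbers for weaker inhibition. Compound 3 has the second highest number of the three: its value sits within the scatter of both compound 2 and compound 1, so none of the three can be called stronger or weaker than compound 3 on these data alone.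

Compound 4 `Cc1cc(Oc2ccc(Cn3nc4ccc(Cl)cc4c3C(=O)NS(=O)(=O)c3ccc([N+](=O)[O-])c(NCc4cccnc4)c3)cc2)cc(C)c1Cl` has not yet been measured. It differs from compound 3 in one place: pyridin-3-yl in place of furan-2-yl on a saturated chain carbon bound to a nitrogen on an aromatic ring. The same exchange has been made once before, on a related core, from compound 1 to compound 2, where it gave a 2.1-fold higher number from compound 1 to compound 2 (0.32 log units; beyond the scatter). Among the compounds with values here, that single step is the only direct guide, and it points to a modest rise in the number for compound 4, that is, somewhat weaker inhibition. The expectation for compound 4 is therefore a step of a 2.1-fold higher number from compound 3 to compound 4 (0.32 log units; beyond the scatter), giving an estimated value of 2000 nM, with a range from 1000 nM to 4200 nM.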

Compound 4, inhibition constant: 1220 nM
Estimate against measurement, compound 4: 1.6-fold (0.21 log units) above, and the stated range covers the measured number.
By their numbers in this assay, from the lowest: compounds 1, 3, 2 and 4 (each within the scatter of the next, the first and the last beyond it).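

On the core of compound 3, pyridin-3-yl in place of furan-2-yl gives a 1.3-fold higher number from compound 3 to compound 4 (0.10 log units; within the scatter), so in this assay these two groups cannot be told apart on this core. A single step on one core could not show whether the exchange would read the same on another, and the two steps now available cannot be separated from each other: the same change on two cores in this assay, a 2.1-fold higher number (0.32 log units; beyond the scatter) from compound 1 to compound 2 and a 1.3-fold higher number (0.10 log units; within the scatter) from compound 3 to compound 4, 1.6-fold (0.21 log units) apart, within the scatter of two such steps. At this place, on a saturated chain carbon bound to a nitrogen on an aromatic ring, the exchange therefore gives at most a modest step on either core, with no large shift on either.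

The compounds shown leave open how this place responds to groups other than these two rings, such as a phenyl ring, a longer alkyl chain or a carboxylic acid. They also leave open whether pyridin-2-yl or pyridin-4-yl would read like pyridin-3-yl.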